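Swapping Methyl for Benzyl on the Selenium of Compound 1

The compounds below may be only part of what the source reports. "The series", "measured", "known", "first", "only" and "open" are said of these compounds alone.

Measured compounds:
- compound 1, `C[Se]/C(=N\C(=O)c1cccs1)NC(=O)c1cccs1`: 1340 nM
- compound 2, `C[Se]/C(=N\C(=O)c1sccc1Cl)NC(=O)c1sccc1Cl`: 970 nM
- compound 3, `O=C(/N=C(/NC(=O)c1cnc2ccccc2c1)[Se]Cc1ccccc1)c1cnc2ccccc2c1`: 34800 nM

All three compounds share a selenium-bearing core flanked by two amide groups. In a functional assay on PC-3 cells (Homo sapiens) for cytotoxicity, read by MTT assay, with a stated time of 72 h (on this read-out higher numbers stand for weaker inhibition of growth and lower numbers for stronger inhibition of growth), compound 1 gives 1340 nM, the second highest of the three numbers. Compound 2, which carries a chlorine on each thiophene, gives 970 nM, and this lies within the scatter of compound 1, so the two cannot be told apart. Compound 3, which has quinoline amides and a benzyl group on the selenium, gives 34800 nM, a number far beyond the scatter from compound 1.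

Compound 4, `O=C(/N=C(/NC(=O)c1cccs1)[Se]Cc1ccccc1)c1cccs1`, keeps the thiophene amides of compound 1 but changes the group on the selenium: phenyl in place of hydrogen on a saturated chain carbon bound to a selenium atom. Going by the values given here, no pair among the measured compounds isolates this change. Compound 3 differs from compound 1 in both the selenium group and the amides. Among the compounds with values here, still, the only compound bearing a benzyl on selenium, compound 3, shows the weakest inhibition, which leans the expectation toward weaker growth inhibition for compound 4. The step from compound 1 to compound 4 in this assay is therefore expected to be a 3.7-fold higher number from compound 1 to compound 4 (0.57 log units; beyond the scatter). Compound 4 is estimated at 5000 nM, with a range from 1500 nM to 20000 nM.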

Compound 4, concentration for 50% growth inhibition: 49900 nM
Estimate against measurement, compound 4: 10-fold (1.00 log units) below; measured number above the stated range.
By their numbers in this assay, from the lowest: compounds 2 and 1 (each within the scatter of the next); then compounds 3 and 4 (each within the scatter of the next).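

Going by these compounds alone, this is the first pair in which the group on the selenium changes while the thiophene amides stay the same: methyl to benzyl gives a 37-fold higher number from compound 1 to compound 4 (1.57 log units; beyond the scatter) in this assay and shows that this position alone can cost a large part of the growth inhibition. Compound 3 could not show this, since it differs from compound 1 in both the amides and the selenium group; now compound 4 at 49900 nM and compound 3 at 34800 nM lie within the scatter of each other, so with benzyl on the selenium these thiophene and quinoline amides cannot be told apart on this read-out. Nothing shown here offers a measured reason for the loss of growth inhibition.

The compounds shown leave open whether the phenyl ring is what matters, since a plain ethyl or propyl chain on the selenium would test whether carbon chains beyond methyl are tolerated without any ring. They also leave open how a benzyl group on the selenium would behave with the chlorine-bearing thiophene amides of compound 2.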